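The source may hold more compounds than are shown below. What is called first, only, known or untested is meant among the compounds shown, and "the series" means these compounds.

In a functional assay on 143B cells (Homo sapiens) for inhibition, read by MTT assay, with a stated time of 72 h (a lower number here means a stronger inhibitor, a higher number a weaker inhibitor), compound 2 (`COc1ccccc1NC(=O)CCC(=O)OCCCCCCSc1ccc([N+](=O)[O-])c2nonc12`) gives 2120 nM and compound 1 (`O=C(CCC(=O)OCCCCCCSc1ccc([N+](=O)[O-])c2nonc12)Nc1ccccc1`) gives 3850 nM, two values within the scatter of each other. Compound 3 (`O=C(CCC(=O)OCCCCCCSc1ccc([N+](=O)[O-])c2nonc12)Nc1cccc(Cl)c1`) carries 3-chlorophenyl in place of 2-methoxyphenyl on an amide-type nitrogen. Going by the values given here, the one measured step bearing on this is a 1.8-fold lower number from compound 1 to compound 2 (0.26 log units; within the scatter), with methoxy in place of hydrogen on an aromatic carbon. Among the compounds with values here, no measured compound carries chlorine. Within the data shown here, with that small step as the only guide, no change beyond the scatter is expected in this assay. The estimated step is a 1.2-fold higher number from compound 2 to compound 3 (0.09 log units; within the scatter). For compound 3 the expected value is 2600 nM, with an estimated range of 1100 nM to 6000 nM.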

Compound 3, half-maximal inhibitory concentration: 2890 nM
Compound 3: the middle estimate sits 1.1-fold (0.05 log units) below what was measured, and the stated range covers the measured number.
By their numbers in this assay, from the lowest: compounds 2, 3 and 1 (each within the scatter of the next).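

In this assay, 3-chlorophenyl in place of 2-methoxyphenyl on the amide-type nitrogen gives a 1.4-fold higher number from compound 2 to compound 3 (0.13 log units; within the scatter), and chloro in place of hydrogen on an aromatic carbon gives a 1.3-fold lower number from compound 1 to compound 3 (0.12 log units; within the scatter). A chlorine-bearing aryl group therefore joins the methoxy-bearing one, and neither separates from the plain phenyl of compound 1 beyond the scatter. Nothing at hand gives a reason for this. Still open, going by these compounds, is whether an amine or a carboxylic acid on this aryl group would move the number beyond the scatter. Also open, on these data alone, is what a longer chain would do in place of the one shared by all three compounds.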